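The compounds below may be only part of what the source reports. "The series", "measured", "known", "first", "only" and "open" are said of these compounds alone.

Measured compounds:
- compound 1, `CC/C(=C(/c1ccc(/C=C/C(=O)O)cc1)c1cc2ccccc2[nH]1)c1cccc(OC(F)(F)F)c1`, a functional assay on MCF7 cells (Homo sapiens) for inhibition; on this read-out higher numbers stand for weaker inhibition and lower numbers for stronger inhibition: 282 nM
- compound 2, `CC/C(=C(/c1ccc(/C=C/C(=O)O)cc1)c1cc2ccccc2[nH]1)c1cccc(Cl)c1Cl`, this assay: 898 nM
- compound 3, `CC/C(=C(/c1ccc(/C=C/C(=O)O)cc1)c1cc2ccccc2[nH]1)c1ccc(Cl)cc1Cl`, this assay: 11 nM

Compound 3 gives the lowest number of the three, with compound 1 nearest at a 26-fold lower number from compound 1 to compound 3 (1.41 log units; beyond the scatter) and compound 2 furthest at an 82-fold lower number from compound 2 to compound 3 (1.91 log units; beyond the scatter); both steps lie beyond the scatter, so compound 3 is the strongest inhibitor among the measured compounds.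

Compound 4, `CC/C(=C(/c1ccc(/C=C/C(=O)O)cc1)c1cc2ccccc2[nH]1)c1cc(Cl)ccc1Cl`, differs from compound 3 by 2,5-dichlorophenyl in place of 2,4-dichlorophenyl on a double-bonded chain carbon bound to a double-bonded chain carbon and a saturated chain carbon. Among the compounds with values here, no measured pair covers the move to a 2,5-dichlorophenyl. The nearest step is an 82-fold lower number from compound 2 to compound 3 (1.91 log units; beyond the scatter), which shows that shifting one chlorine on the same dichlorophenyl changes the number by a large amount, and a 26-fold lower number from compound 1 to compound 3 (1.41 log units; beyond the scatter) shows the 2,4-dichlorophenyl as the best group seen. Within the data shown here, compound 4 is therefore expected to give a higher number than compound 3, with a step of an 11-fold higher number from compound 3 to compound 4 (1.04 log units; beyond the scatter), though the direction rests on only two steps. The estimate for compound 4 is 120 nM, within 15 nM to 900 nM.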

Compound 4, half-maximal inhibitory concentration: 71 nM
Beside the measured number, compound 4's estimate is 1.7-fold (0.23 log units) above it; the range from low to high includes it.
By their numbers in this assay, from the lowest: compound 3; then compound 4; then compound 1; then compound 2.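

With the same atoms on the ring, the 2,5-dichlorophenyl gives up part of the strength of the 2,4-dichlorophenyl (a 6.5-fold higher number from compound 3 to compound 4 (0.81 log units; beyond the scatter)) but stands well ahead of the 2,3-dichlorophenyl (a 13-fold lower number from compound 2 to compound 4 (1.10 log units; beyond the scatter)) in this assay, so at this place the three chlorine patterns form a graded order, not one good pattern and two poor ones. The 2,5-dichlorophenyl also improves on the 3-(trifluoromethoxy)phenyl (a 4.0-fold lower number from compound 1 to compound 4 (0.60 log units; beyond the scatter)), which makes two of the three dichlorophenyl groups stronger than that group, with compound 2 going against this by falling behind it. Nothing measured explains why the chlorine pattern matters so much here.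

Open, as far as these compounds go, is how a single chlorine, as in a 4-chlorophenyl, or a methoxy or nitrile group would read at this place. Also open, from the compounds shown here alone, is whether the same order holds with an amide in place of the carboxylic acid.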